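The source may report more compounds than this note shows. Statements on the series, on what has been measured and on what is new or still open speak of the compounds shown alone.

Compound 1, `ClCc1cccc(Cn2cnc3c(Cl)nc(Cl)nc32)c1` — in a functional assay on MOLT-4 cells (Homo sapiens) for cytotoxicity, read by sulforhodamine B assay, with a stated time of 48 h (on this read-out higher numbers stand for weaker inhibition of growth and lower numbers for stronger inhibition of growth), compound 1 gives > 100000 nM.
Compound 2, `Nc1nc(Cl)c2ncn(Cc3ccccc3CCl)c2n1` — in this assay compound 2 gives > 100000 nM.

The value of compound 1 is a limit of this assay and not a number. The value of compound 2 is likewise a limit and not a number. For the measured compounds named here, compound 2 therefore stands at the same place as the only other measured compound: both sit at the limit of > 100000 nM in this assay, at which 2 of the 2 values shown sit, and no measured step between compounds that differ in one place is available.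

Compound 3, `ClCc1ccccc1Cn1cnc2c(Cl)ncnc21`, is not yet measured. It differs from compound 2 in one place: hydrogen in place of amino on an aromatic carbon. Since compound 2 gives only a limit in this assay, no size of step can be read from the numbers shown, and no step beyond the scatter is expected in either direction. Compound 3 is expected to give about 100000 nM, within 40000 nM to 300000 nM, a change of a number no higher from compound 2 to compound 3 (the limit leaves the size open).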

Compound 3, concentration for total growth inhibition: 5240 nM
Compound 3: the middle estimate sits 19-fold (1.28 log units) above what was measured; measured number below the stated range.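

In this assay, the position on the six-membered aromatic ring between two ring nitrogen atoms proves to matter: hydrogen in place of amino gives an at least 19-fold lower number from compound 2 to compound 3 (1.28 log units; beyond the scatter). This is the first measured step among these compounds, and compound 3 is the first to give a number rather than a limit, so growth inhibition can now be read at all. Only the minimum size of the step is known, since the value of compound 2 is a limit and not a number: the limit of > 100000 nM in this assay, at which 2 of the 3 values shown sit.

On these data alone, it remains open whether any group other than hydrogen at this position, such as methyl or methoxy, would keep the stronger inhibition of growth. Compound 1 differs from compound 3 in more than one place, so the compounds shown cannot tell what its other differences contribute.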